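A few compounds are considered here, and "the series" means these few. Any claim that something is new, unique, unknown or untested is made for them only; others in the source may bear on it.

In a functional assay on PC-3 cells (Homo sapiens) for cytotoxicity, read by MTT assay (a higher number here means a weaker inhibitor, a lower number a stronger inhibitor), compound 3 `COc1ccc2cc([C@H](C)c3nnc(SCc4ccc(Cl)cc4)n3-c3ccc(Cl)cc3)ccc2c1` gives 5800 nM, the lower of the two readable numbers. Compound 2 `COc1ccc2cc([C@H](C)c3nnc(SCc4ccc(C)cc4)n3-c3ccc(F)cc3)ccc2c1` gives 229000 nM, a gap well beyond the scatter, although the two compounds differ in two places. Compound 1 `COc1ccc2cc([C@H](C)c3nnc(SCc4ccc(Cl)cc4)n3-c3ccc(F)cc3)ccc2c1` has only a limit, <= 400000 nM.

The next step leads to compound 4 `COc1ccc2cc([C@H](C)c3nnc(SCc4ccc(C)cc4)n3-c3ccc(Cl)cc3)ccc2c1`. The change is methyl in place of chloro on an aromatic carbon, para to a large group, so that 4-chlorobenzyl becomes 4-methylbenzyl.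

The same exchange has been measured once, as a step that the limit leaves unreadable from compound 1 to compound 2. The other measured step, chloro in place of fluoro, is a step that the limit leaves unreadable from compound 1 to compound 3. Neither size can be read because the limit of <= 400000 nM in this assay, at which 1 of the 3 values shown sits, takes the place of a number for compound 1. The closest remaining guide is compound 2, which carries the 4-methylbenzyl group and gives 229000 nM in this assay. On that basis a higher number is expected, though the size of the rise is poorly defined. The estimated move is a 2.6-fold higher number from compound 3 to compound 4 (0.41 log units; beyond the scatter), towards a weaker inhibitor. Compound 4 is expected at 15000 nM, with an estimated range from 4000 nM to 120000 nM.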

Compound 4, half-maximal inhibitory concentration: 8400 nM
Compound 4: middle estimate off by 1.8-fold (0.25 log units), on the high side, and the stated range covers the measured number.
By their numbers in this assay, from the lowest: compounds 3 and 4 (each within the scatter of the next); then compound 2.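

In this assay, among these compounds, the exchange of 4-chlorobenzyl for 4-methylbenzyl now has a readable size for the first time, a 1.4-fold higher number from compound 3 to compound 4 (0.16 log units; within the scatter), so in this pair the two groups cannot be told apart. The chloro in place of fluoro exchange also gets its first readable size, a 27-fold lower number from compound 2 to compound 4 (1.44 log units; beyond the scatter), which shows that with 4-methylbenzyl held constant, this single halogen exchange carries a large change towards a stronger inhibitor. Set side by side, the two steps show that here the halogen exchange matters far more than the group para to a large group on the benzyl side, although this rests on one step of each kind.

From the compounds shown here alone, the steps from compound 1 still cannot be read, because its entry is a limit and not a number: the limit of <= 400000 nM in this assay, at which 1 of the 4 values shown sits. It therefore remains open whether the methyl for chloro exchange is as small alongside fluoro, and whether a methoxy, an amine or a carboxylic acid in place of the chloro of 4-chlorobenzyl would also stay within the scatter.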